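The source may report more compounds than this note shows. Statements on the series, on what has been measured and on what is new or still open speak of the compounds shown alone.

The measured compounds so far:

Compound 1 `CSc1cc(C)nc(SC)c1NC(=O)N(Cc1cccc(Oc2ccc(Br)cc2)c1)C1CCCCCC1` — 73 nM
Compound 2 `CSc1cc(C)nc(SC)c1NC(=O)N(Cc1ccccc1)Cc1ccc(Oc2ccc(F)cc2)cc1` — 9.1 nM
Compound 3 `CSc1cc(C)nc(SC)c1NC(=O)N(Cc1ccc(Oc2ccc(Br)cc2)cc1)C1CCCCCC1` — 28 nM

All three share the same core and were tested in an assay for inhibition of acyl-CoA:cholesterol acyltransferase (Oryctolagus cuniculus), using microsomes; on this read-out higher numbers stand for weaker inhibition and lower numbers for stronger inhibition. On the numbers shown, compound 3 stands second highest of the three: in this assay compound 3 gives 28 nM, compound 1 gives 73 nM, and compound 2 gives 9.1 nM. Compound 2, the one carrying a benzyl on the amide-type nitrogen, shows the lowest number of the set.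

Compound 4 `CSc1cc(C)nc(SC)c1NC(=O)N(Cc1ccccc1)Cc1ccc(Oc2ccc(Br)cc2)cc1` has not yet been measured. It differs from compound 3 in one place: benzyl in place of cycloheptyl on an amide-type nitrogen. Since compound 2 also carries a benzyl at that nitrogen and gives 9.1 nM, the change is expected to move the number downward, to a step of about a 2.3-fold lower number from compound 3 to compound 4 (0.37 log units; beyond the scatter), somewhat beyond the scatter. Compound 4 is therefore estimated at 12 nM, within a range from 5 nM to 30 nM.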

Compound 4, half-maximal inhibitory concentration: 10 nM
Beside the measured number, compound 4's estimate is 1.2-fold (0.08 log units) above it, and the stated range covers the measured number.
By their numbers in this assay, from the lowest: compounds 2 and 4 (each within the scatter of the next); then compound 3; then compound 1.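

In this assay, going by these compounds alone, benzyl in place of cycloheptyl on the amide-type nitrogen gives a 2.8-fold lower number from compound 3 to compound 4 (0.45 log units; beyond the scatter), which is the first direct reading of this change between two compounds that differ only there, and the two groups have the same count of heavy atoms. With benzyl at that nitrogen, bromo in place of fluoro on the aromatic carbon gives a 1.1-fold higher number from compound 2 to compound 4 (0.04 log units; within the scatter), so this exchange stays within the usual scatter. The data shown offer no measurement that explains either result.

On these data alone, whether the lower number extends to other groups at this nitrogen, such as cyclohexyl, phenethyl or a piperidine, remains open. Also open, as far as these compounds go, is whether bromo and fluoro still match with cycloheptyl at the nitrogen, and how chloro or methoxy would compare on that aromatic carbon.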